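Aryl variation on the triazole nitrogen: compound 4

The source may hold more compounds than are shown below. What is called first, only, known or untested is meant among the compounds shown, and "the series" means these compounds.

Measured compounds:
compound 1 `CC1(C)[C@H]2CC[C@]1(C)N(Cc1cn(-c3cccc(Cl)c3)nn1)C(=O)C2` 50 nM
compound 2 `COc1ccccc1-n1cc(CN2C(=O)C[C@@H]3CC[C@@]2(C)C3(C)C)nn1` 140 nM
compound 3 `CC1(C)[C@H]2CC[C@]1(C)N(Cc1cn(-c3ccccc3)nn1)C(=O)C2` 50 nM

In a functional assay on OVCAR-3 cells (Homo sapiens) for inhibition, read by MTT assay, with a stated time of 24 h (a lower number here means a stronger inhibitor, a higher number a weaker inhibitor), compound 1 stands level with compound 3, the two lowest numbers of the three; compound 2 is furthest, with a 2.8-fold higher number from compound 1 to compound 2 (0.45 log units; beyond the scatter). The change no change at the digits printed from compound 1 to compound 3 (within the scatter) shows that removing the chloro leaves the number unchanged.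

Compound 4 `CC1(C)[C@H]2CC[C@]1(C)N(Cc1cn(-c3ccccc3Br)nn1)C(=O)C2` differs from compound 1 by 2-bromophenyl in place of 3-chlorophenyl on an aromatic nitrogen. The step from compound 1 to compound 2 is the nearest guide, a 2-methoxyphenyl in the same position having raised the number modestly; no halogen at that position has been measured. A modest rise is therefore expected, a 2.0-fold higher number from compound 1 to compound 4 (0.30 log units; within the scatter), with compound 4 estimated at 100 nM, range 50 nM to 200 nM.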

Compound 4, half-maximal inhibitory concentration: 140 nM
The estimate for compound 4 lay 1.4-fold (0.15 log units) below the measured number, and the stated range covers the measured number.
By their numbers in this assay, from the lowest: compounds 1 and 3 (each within the scatter of the next); then compounds 2 and 4 (each within the scatter of the next).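

In this assay, bromo in place of hydrogen raises the number, a 2.8-fold higher number from compound 3 to compound 4 (0.45 log units; beyond the scatter), whereas the chloro of compound 1 left it level with the plain phenyl. Replacing 3-chlorophenyl with 2-bromophenyl gives the same rise, a 2.8-fold higher number from compound 1 to compound 4 (0.45 log units; beyond the scatter). The 2-bromophenyl and 2-methoxyphenyl groups read alike, no change at the digits printed from compound 2 to compound 4 (within the scatter), so these two groups stand apart from phenyl and 3-chlorophenyl across the four compounds.

Nothing at hand accounts for this difference. Open, from the compounds shown here alone, is whether 3-bromophenyl or 2-chlorophenyl would read with compound 1 or with compound 4, and how an amine or a carboxylic acid on the phenyl would read.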